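A few compounds are considered here, and "the series" means these few. Any claim that something is new, unique, unknown or untested is made for them only; others in the source may bear on it.

Three thiourea compounds sharing the same core have been examined in an ADME assay on isolated protein for inhibition of peroxidase (Raphanus sativus), read by fluorescence and Amplex Red, tested at 5 uM; a lower number here means a stronger effect, a higher number a weaker effect of the compound at the concentration tested. Compound 1 `S=C(Nc1ccccc1)Nc1ccc2[nH]ccc2c1` gives 81.4%. Compound 2 `Oc1ccccc1NC(=S)Nc1ccc2[nH]ccc2c1` gives 43.9%, and compound 3 `S=C(Nc1ccc2[nH]ccc2c1)Nc1cccc2cnccc12` gives 63.3%. Among these three numbers compound 2 stands lowest, meaning the strongest effect, with compound 3 the nearest to it and compound 1 the furthest away. Going by the values given here, the one step between compounds differing in a single place is a number 37.5 percentage points lower from compound 1 to compound 2 (beyond the scatter).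

Compound 4 `Cc1ccc(NC(=S)Nc2ccc3[nH]ccc3c2)c(O)c1` has not yet been measured. It differs from compound 2 by methyl in place of hydrogen on an aromatic carbon. Among the compounds with values here, no measured step involves a methyl group, so the only known step, from compound 1 to compound 2, concerns a different change and does not bear directly on this one. Without a comparable step, the expectation for compound 4 is a change of about none beyond the scatter, so that the estimated step is a number 1.1 percentage points higher from compound 2 to compound 4 (within the scatter). Compound 4 is therefore estimated at 45%, with a range from 25% to 65%.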

Compound 4, a percentage reported as activity, at one concentration (the size of the read-out at that concentration, not a potency): 47.3%
The estimate for compound 4 lay 2.3 percentage points below the measured number, and the stated range covers the measured number.
By their numbers in this assay, from the lowest: compounds 2 and 4 (each within the scatter of the next); then compound 3; then compound 1.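

With methyl in place of hydrogen on an aromatic carbon, meta to the hydroxy group and para to a large group, this assay gives a number 3.4 percentage points higher from compound 2 to compound 4 (within the scatter), so the two compounds cannot be told apart in this assay. This position therefore carries a methyl group while the much lower number that came with the hydroxy group in compound 2 remains in place. No measurement at hand offers an explanation for this outcome.

Going by these compounds, whether an ethyl group, a methoxy group, an amine or a carboxylic acid at this same position would give a similar number remains open. On these data alone, it is also open whether methyl here would give the same outcome without the hydroxy group, on the otherwise unsubstituted ring of compound 1.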